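From 3-methylphenyl to 4-isopropylphenyl on the shared core

A few compounds are considered here, and "the series" means these few. Any claim that something is new, unique, unknown or untested is made for them only; others in the source may bear on it.

Three compounds built on the shared core of compound 1 `Cc1cc(=O)oc2cc(OCc3nc(N)nc(Nc4ccc(Cl)cc4)n3)ccc12` have been measured in an assay on COS-7 cells for agonist activity at Free fatty acid receptor 1 (Homo sapiens), read by scintillation counting and inositol phosphate accumulation, with a stated time of 90 min; a lower number here means that less compound is needed, a higher number that more compound is needed for the effect. Compound 1 gives 32500 nM. Compound 2 `Cc1cccc(Nc2nc(N)nc(COc3ccc4c(C)cc(=O)oc4c3)n2)c1` gives 1780 nM, and compound 3 `Cc1cc(=O)oc2cc(OCc3nc(N)nc(Nc4cccc(Cl)c4)n3)ccc12` gives 1110 nM. Compound 2 thus stands second highest of the three numbers, close to compound 3, since the step of a 1.6-fold lower number from compound 2 to compound 3 (0.21 log units; within the scatter) lies within the scatter, and far from compound 1, the step of an 18-fold lower number from compound 1 to compound 2 (1.26 log units; beyond the scatter) lying well beyond it.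

Compound 4 `Cc1cc(=O)oc2cc(OCc3nc(N)nc(Nc4ccc(C(C)C)cc4)n3)ccc12` has not yet been measured. It differs from compound 2 as follows: 4-isopropylphenyl in place of 3-methylphenyl on a nitrogen on an aromatic ring. The measured steps that bear on this change are an 18-fold lower number from compound 1 to compound 2 (1.26 log units; beyond the scatter) and a 29-fold lower number from compound 1 to compound 3 (1.47 log units; beyond the scatter), both large; in each a 4-chlorophenyl gave way to a 3-substituted phenyl and the number fell sharply. Compound 4 runs the other way, back to a phenyl of the 4-chlorophenyl kind, with isopropyl rather than chloro, for which no measured comparison exists. A number higher than that of compound 2 is therefore expected, though with wide uncertainty. Compound 4 is estimated at 8000 nM, between 1500 nM and 40000 nM, an expected step of a 4.5-fold higher number from compound 2 to compound 4 (0.65 log units; beyond the scatter).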

Compound 4, half-maximal effective concentration: 460 nM
The estimate for compound 4 lay 17-fold (1.24 log units) above the measured number; the whole stated range lies above it.
By their numbers in this assay, from the lowest: compound 4; then compounds 3 and 2 (each within the scatter of the next); then compound 1.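

Isopropyl in place of chloro on an aromatic carbon gives a 71-fold lower number from compound 1 to compound 4 (1.85 log units; beyond the scatter), so the high number of compound 1 belongs to 4-chlorophenyl in particular and not to every group of this kind on the nitrogen. The 4-isopropylphenyl group also goes past both 3-substituted groups, with a 3.9-fold lower number from compound 2 to compound 4 (0.59 log units; beyond the scatter) and a 2.4-fold lower number from compound 3 to compound 4 (0.38 log units; beyond the scatter), two modest steps beyond the scatter that leave compound 4 with the lowest number of the four. Nothing measured here accounts for these differences.

The compounds shown leave open whether 3-isopropylphenyl would match 4-isopropylphenyl, and whether 4-methylphenyl would fall nearer compound 1 or compound 4. They also leave open how a longer chain such as butyl, or a carboxylic acid, would fare on the same phenyl ring.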